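Three Compounds at the Limit and One Still Unmeasured

This account rests on a few compounds, and the source may have more. Where it says the series, first, only, none or still open, it means among the compounds named here.

Measured so far:
compound 1, `O=C1OC(Cc2nc(-c3ccc(Oc4ccccc4)cc3)no2)c2ccccc21`, gives a limit: > 10000 nM
compound 2, `O=C1OC(Cc2nc(-c3ccc(-c4ccccc4)cc3)no2)c2ccccc21`, gives a limit: > 10000 nM
compound 3, `COCCOc1ccc(C(O)C2OC(=O)c3c(OC)cc(OC)cc32)cc1`, gives a limit: > 10000 nM

In a functional assay on RAW264.7 cells (Mus musculus) for inhibition, read by Griess assay, with stated times of 1 h and 24 h (on this read-out lower numbers stand for stronger inhibition and higher numbers for weaker inhibition), compound 1 reaches only a limit, > 10000 nM. Compound 2 likewise gives a limit, > 10000 nM. Compound 3 also gives a limit, > 10000 nM. The step that the two limits leave unreadable from compound 1 to compound 2 cannot be read, since both ends are limits. All three values sit at the same point, (the limit of > 10000 nM in this assay, at which 3 of the 3 values shown sit), so compound 3 stands at that limit together with the others and no number places it above or below them.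

Compound 4, `COc1cc(OC)c2c(c1)C(C(O)c1ccc(OCc3ccc(C)cc3)cc1)OC2=O`, differs from compound 3 by 4-methylphenyl in place of methoxymethyl on a saturated chain carbon bound to an oxygen on an aromatic ring. No measured step bears on this change: the one step shown, a step that the two limits leave unreadable from compound 1 to compound 2, is unreadable and concerns a different part of the structure. The step from compound 3 to compound 4 is therefore expected to be a step that the limit leaves unreadable from compound 3 to compound 4, with no readable basis for a direction. Compound 4 is estimated at 15000 nM, in a range from 3000 nM to 80000 nM, and is expected most likely to return a limit again.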

Compound 4, half-maximal inhibitory concentration: 3120 nM
Compound 4: the middle estimate sits 4.8-fold (0.68 log units) above what was measured; low and high end bracket the measured number.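

In this assay, the swap on a saturated chain carbon bound to an oxygen on an aromatic ring gives the first readable step among these compounds, an at least 3.2-fold lower number from compound 3 to compound 4 (0.50 log units; beyond the scatter), and that step is beyond the scatter. Within the data shown here, this shows that the position can shift the read-out, with 4-methylbenzyl in place of 2-methoxyethyl, whereas the one earlier step could not be read; the size is only a lower bound, as compound 3 has a limit as its value. Compound 4 is the one compound shown that has a number and not a limit: the limit of > 10000 nM in this assay, at which 3 of the 4 values shown sit.

The compounds shown leave open whether the gain needs the ring alone or also its methyl, which an unsubstituted benzyl or a 4-chlorobenzyl group would test, and whether a plain butyl chain would do the same. They also leave open whether a (4-methylbenzyl)oxy group would have any such effect on the core of compound 1.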